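The compounds below may be only part of what the source reports. "The series", "measured", "known", "first", "only" and "open" are said of these compounds alone.

Series notes, a physicochemical assay for solubility, with a stated time of 18 h, at pH 7.4; a lower number here means a less soluble compound, a higher number a more soluble compound:

- compound 1, `COc1ccc(F)cc1CNCCCNc1ccnc2cc(Oc3ccc(C(C)(C)C)cc3)ccc12`, gives 14500 nM
- compound 2, `CC(C)(C)c1ccc(Oc2ccc3c(NCCCNCc4ccco4)ccnc3c2)cc1`, gives 14500 nM
- compound 3, `COc1cccc(CNCCCNc2ccnc3cc(Oc4ccc(C(C)(C)C)cc4)ccc23)c1O`, gives 14500 nM

Compound 1 stands level with compounds 2 and 3 in this assay. The three measured steps, no change at the digits printed from compound 1 to compound 2 (within the scatter), no change at the digits printed from compound 1 to compound 3 (within the scatter) and no change at the digits printed from compound 2 to compound 3 (within the scatter), all concern the aryl group on the saturated chain carbon bound to the amine nitrogen, and none of them moves the read-out beyond the scatter.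

Compound 4, `COc1ccc(F)cc1CNCCCNc1ccnc2cc(-c3ccc(C(C)(C)C)cc3)ccc12`, differs from compound 1 at the other end of the molecule: 4-(tert-butyl)phenyl in place of 4-(tert-butyl)phenoxy on an aromatic carbon. Among the compounds with values here, no measured step touches this position, so the unchanged values of compounds 1, 2 and 3 give no direct guide to it. Given the absence of any comparable step, the expectation for this assay is a step from compound 1 to compound 4 that is small, a 1.5-fold lower number from compound 1 to compound 4 (0.16 log units; within the scatter), with a wide range on either side. Compound 4 is therefore estimated at 10000 nM, between 3500 nM and 30000 nM.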

Compound 4, solubility: 32000 nM
Estimate against measurement, compound 4: 3.2-fold (0.51 log units) below; measured number above the stated range.
By their numbers in this assay, from the lowest: compounds 1, 2 and 3 (each within the scatter of the next); then compound 4.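

In this assay, within the data shown here, 4-(tert-butyl)phenyl in place of 4-(tert-butyl)phenoxy on this aromatic carbon gives a 2.2-fold higher number from compound 1 to compound 4 (0.34 log units; beyond the scatter), the only step in the set beyond the scatter. The read-out therefore responds to this change, modestly, whereas the aryl swaps on the saturated chain carbon bound to the amine nitrogen left it level. The entering group lacks the oxygen and the hydrogen-bond acceptor of the leaving group, but no measurement given here explains the step, which rests on a single pair.

Whether the step carries over to the furan-2-yl or 2-hydroxy-3-methoxyphenyl partners remains open, since the compounds shown pair those groups only with 4-(tert-butyl)phenoxy. Going by these compounds, the effect of an amine or carbonyl link to the 4-(tert-butyl)phenyl group also remains open.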